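A few compounds are considered here, and "the series" means these few. Any claim that something is new, unique, unknown or untested is made for them only; others in the source may bear on it.

In a functional assay on BeWo cells (Homo sapiens) for inhibition, read by MTT assay, with a stated time of 72 h (a higher number here means a weaker inhibitor, a lower number a stronger inhibitor), the measured members of the series:

- compound 1 `CN1CCN(c2nnc3nncn3n2)CC1`: 7990 nM
- compound 2 `CCC(=O)N1CCN(c2nnc3nncn3n2)CC1`: 13700 nM
- compound 3 `CCCC(=O)N1CCN(c2nnc3nncn3n2)CC1`: 6730 nM

Compound 3 has the lowest number of the three in this assay. The step of a 1.2-fold lower number from compound 1 to compound 3 (0.07 log units; within the scatter) is within the scatter, so the two cannot be ordered; the step of a 2.0-fold lower number from compound 2 to compound 3 (0.31 log units; beyond the scatter) is beyond the scatter, a modest gain. All three share the same core and differ only in the group on an amine nitrogen in a ring.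

Compound 4 `CC(C)(C)C(=O)N1CCN(c2nnc3nncn3n2)CC1` is not yet measured. It differs from compound 3 thus: tert-butyl in place of propyl on a carbonyl carbon. The step that bears most directly is a 2.0-fold lower number from compound 2 to compound 3 (0.31 log units; beyond the scatter), where lengthening the acyl chain gave a modest lowering. The steps of a 1.7-fold higher number from compound 1 to compound 2 (0.23 log units; within the scatter) and a 1.2-fold lower number from compound 1 to compound 3 (0.07 log units; within the scatter) show that swapping methyl for either acyl group left the number within the scatter. Enlarging the acyl group has therefore moved the number little, in the direction of lower values. Expected for compound 4: a 1.2-fold lower number from compound 3 to compound 4 (0.09 log units; within the scatter), most likely within the scatter, with a small lowering the likelier side. The estimate for compound 4 is 5500 nM, with a range from 2500 nM to 12000 nM.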

Compound 4, half-maximal inhibitory concentration: 2410 nM
For compound 4 the middle estimate is 2.3-fold (0.36 log units) above the measured one, outside the stated range (below it).
By their numbers in this assay, from the lowest: compound 4; then compounds 3, 1 and 2 (each within the scatter of the next, the first and the last beyond it).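

In this assay, going by these compounds alone, tert-butyl in place of propyl on the carbonyl carbon gives a 2.8-fold lower number from compound 3 to compound 4 (0.45 log units; beyond the scatter) and is the first change at this position to set one compound apart from all the others. Tert-butyl in place of ethyl gives a 5.7-fold lower number from compound 2 to compound 4 (0.75 log units; beyond the scatter) and (tert-butyl)carbonyl in place of methyl on the amine nitrogen gives a 3.3-fold lower number from compound 1 to compound 4 (0.52 log units; beyond the scatter), so compound 4 is the strongest inhibitor of the four, and the group on this carbonyl carbon can move the number beyond the scatter. Nothing at hand accounts for the lowering.

The compounds shown do not separate the branching of tert-butyl from its one extra carbon, which a straight butyl chain on the same carbonyl carbon would address. On these data alone, it also remains open whether a cyclopropyl or cyclohexyl group there would give a lower number still.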